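Swapping chloro for methoxy on an aromatic carbon

This account rests on a few compounds, and the source may have more. Where it says the series, first, only, none or still open, it means among the compounds named here.

Compound 1 `COc1ccc2c(c1)c(C1CC(c3ccc(F)cc3)=NN1C(=O)c1ccc(OC)nc1)cn2C`: 220 nM
Compound 2 `COc1ccc2c(c1)c(C1CC(c3ccc(Cl)cc3)=NN1C(=O)c1ccc(OC)nc1)cn2C`: 2080 nM
Compound 3 `COc1ccc(C2=NN(C(=O)c3ccc(OC)nc3)C(c3cn(C)c4ccc(OC)cc34)C2)cc1`: not yet measured

In a functional assay on HepG2 cells (Homo sapiens) for inhibition, read by MTT assay, with a stated time of 48 h (on this read-out higher numbers stand for weaker inhibition of growth and lower numbers for stronger inhibition of growth), compound 2 gives 2080 nM, the higher of the two numbers. Compound 3 changes one group, 4-chlorophenyl to 4-methoxyphenyl: methoxy in place of chloro on an aromatic carbon. Among the compounds with values here, only one measured step bears on this, a swap on the same aromatic carbon: a 9.5-fold higher number from compound 1 to compound 2 (0.98 log units; beyond the scatter). With so little data the direction stays uncertain, but a step no larger than that one is expected, more likely towards lower numbers. The estimated change is a 2.3-fold lower number from compound 2 to compound 3 (0.36 log units; beyond the scatter). For compound 3 the expected value is 900 nM, with an estimated range of 150 nM to 4000 nM.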

Compound 3, concentration for 50% growth inhibition: 230 nM
The estimate for compound 3 lay 3.9-fold (0.59 log units) above the measured number; the measured number falls inside the stated range.
By their numbers in this assay, from the lowest: compounds 1 and 3 (each within the scatter of the next); then compound 2.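

Within this assay methoxy in place of chloro on this aromatic carbon gives a 9.0-fold lower number from compound 2 to compound 3 (0.96 log units; beyond the scatter) and so the high number of compound 2 goes with chloro, not with every change at this position. Methoxy in place of fluoro gives a 1.0-fold higher number from compound 1 to compound 3 (0.02 log units; within the scatter) and so these two groups cannot be told apart on this read-out. Nothing available explains why chloro alone stands apart. Open, on these data alone, is how an amine, a hydroxyl or a carboxylic acid on this carbon would compare with these three groups.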